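From Dimethylphenyl to Difluorophenyl: Expecting Little Change

The source may hold more compounds than are shown below. What is called first, only, known or untested is meant among the compounds shown, and "the series" means these compounds.

Of the compounds shown here, two have so far been measured in an assay on isolated protein for inhibition of Ephrin type-A receptor 2 (Homo sapiens), read by thermal shift assay, tested at 10 uM; a higher number here means that the compound stabilises the target more against heat, a lower number that the compound stabilises the target less. Compound 1 `Cc1cc(C)cc(NC(=O)Nc2cc(C(C)(C)C)nn2-c2ccccc2)c1` gives 0.7 degrees C in this assay, and compound 2 `CC(C)(C)c1cc(NC(=O)Nc2cc(C(F)(F)F)cc(C(F)(F)F)c2)n(-c2ccc(F)cc2)n1` gives 0.4 degrees C. The two numbers lie within the scatter of each other, so neither compound can be said to stabilise the target more than the other; both shifts are modest. Compound 3 `CC(C)(C)c1cc(NC(=O)Nc2cc(F)cc(F)c2)n(-c2ccccc2)n1` has not yet been measured. It differs from compound 1 in one place: 3,5-difluorophenyl in place of 3,5-dimethylphenyl on an amide-type nitrogen. Going by the values given here, no step between measured compounds that differ in a single place is known here, so the size of this change cannot be read from a precedent. Compound 2, which also carries fluorine, gives 0.4 degrees C, a value in the same small region as compound 1. Compound 3 is therefore expected to give 0.5 degrees C, with a range from -0.5 degrees C to 1.5 degrees C. The expected step of a number 0.20 degrees C lower from compound 1 to compound 3 (within the scatter) is estimated to lie within the scatter, with no clear direction.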

Compound 3, shift of the target's melting temperature: 2.7 degrees C
Estimate against measurement, compound 3: 2.2 degrees C below; measured number outside the range, above it.
By their numbers in this assay, from the lowest: compounds 2 and 1 (each within the scatter of the next); then compound 3.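

Going by these compounds alone, exchanging 3,5-dimethylphenyl for 3,5-difluorophenyl on an amide-type nitrogen gives a number 2.0 degrees C higher from compound 1 to compound 3 (beyond the scatter) in this assay and provides the first single-place step in this set. It shows that this position responds to the exchange, even though both groups have the same heavy-atom count, one six-membered aromatic ring of carbon only, no hydrogen-bond donors or acceptors and no net charge. No measurement available here accounts for the step.

The compounds shown leave open whether a 3,5-dichlorophenyl group, a 3,5-dimethoxyphenyl group or an unsubstituted phenyl group at this place would give a number closer to that of compound 1 or that of compound 3. They also leave open whether the same exchange would produce a similar step with other groups elsewhere on the shared core.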